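Methoxy in Place of Methyl: Expecting Compound 3

The source may hold more compounds than are shown below. What is called first, only, known or untested is meant among the compounds shown, and "the series" means these compounds.

Compound 2 `Cc1cccc(C(=O)NN(C(=O)c2ccccc2Cl)C(C)(C)C)c1C` gives the lowest of the two numbers measured in an assay on cells for agonist activity at ecdysone receptor (Bombyx mori), read by a luciferase reporter, with a stated time of 24 h (a lower number here means that less compound is needed, a higher number that more compound is needed for the effect), namely 20 nM. Compound 1 `Cc1ccccc1C(=O)NN(C(=O)c1ccccc1Cl)C(C)(C)C` gives 72.4 nM in this assay, and the step of a 3.6-fold lower number from compound 1 to compound 2 (0.56 log units; beyond the scatter) came from a methyl in place of hydrogen on an aromatic carbon. Compound 3 `COc1cccc(C(=O)NN(C(=O)c2ccccc2Cl)C(C)(C)C)c1C` differs from compound 2 by methoxy in place of methyl on an aromatic carbon. Within the data shown here, no measured step swaps methyl for methoxy, so the single measured step gives only an indirect hint, and a change beyond the scatter is not expected in either direction. Compound 3 is therefore estimated at 30 nM, within 8 nM to 120 nM. The expected step is a 1.5-fold higher number from compound 2 to compound 3 (0.18 log units; within the scatter).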

Compound 3, half-maximal effective concentration: 15.5 nM
For compound 3 the middle estimate is 1.9-fold (0.29 log units) above the measured one; measured number inside the range.
By their numbers in this assay, from the lowest: compounds 3 and 2 (each within the scatter of the next); then compound 1.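

At this position, ortho to a methyl group, methoxy and methyl cannot be told apart: the change gives a 1.3-fold lower number from compound 2 to compound 3 (0.11 log units; within the scatter). Measured against hydrogen, methoxy gives a 4.7-fold lower number from compound 1 to compound 3 (0.67 log units; beyond the scatter), so the benefit of filling this position is not tied to methyl alone, even though methoxy is larger and adds a hydrogen-bond acceptor. The compounds shown leave open whether an amine, a chlorine or a longer chain such as ethoxy would also be tolerated here. Nothing at hand explains why methyl and methoxy match at this position.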